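The source may hold more compounds than are shown below. What is called first, only, known or untested is meant among the compounds shown, and "the series" means these compounds.

Series in a functional assay on brain (Rattus norvegicus, strain Wistar) for inhibition; on this read-out higher numbers stand for weaker inhibition and lower numbers for stronger inhibition
compound 1 `CCCCCCCCOc1ccc(-c2c(C)[nH]c(=O)n2C)cc1`: 4000 nM
compound 2 `CCCCCCCCCCCOc1ccc(-c2c(C)[nH]c(=O)n2C)cc1`: 9700 nM

Compound 2, at 9700 nM, holds the higher of the two numbers, which makes it the weaker inhibitor of the pair. Compound 3 `CCCCCCCCCCCCCCCCCCOc1ccc(-c2c(C)[nH]c(=O)n2C)cc1` has not yet been measured and carries heptyl in place of hydrogen on a saturated chain carbon, ten or more bonds along the chain from an oxygen on an aromatic ring. The shared core stays untouched, and only the chain grows longer. For the measured compounds named here, one measured step bears on this change: a 2.4-fold higher number from compound 1 to compound 2 (0.38 log units; beyond the scatter), which is modest but beyond the scatter. Going by the values given here, the extension in compound 3 is larger than the one in that step, so a rise of similar or somewhat greater size is expected in this assay, in the direction of weaker inhibition. Among the compounds with values here, a single step fixes no slope, and no measurement yet shows whether the trend holds this far along the chain, so a full proportional carry-over is not assumed. The expected step is a 3.1-fold higher number from compound 2 to compound 3 (0.49 log units; beyond the scatter). For compound 3 the estimated value is 30000 nM, with an expected range of 9000 nM to 100000 nM.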

Compound 3, half-maximal inhibitory concentration: > 100000 nM
Compound 3: a limit, no number; the forecaster's own chance of this, stated with the estimate: 25%; middle value at least 3.3-fold (0.52 log units) from the limit.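

In this assay compound 3 gives > 100000 nM, which is a limit of the assay and not a number. Heptyl in place of hydrogen on a saturated chain carbon gives an at least 10-fold higher number from compound 2 to compound 3 (1.01 log units; beyond the scatter), and the whole extension by decyl gives an at least 25-fold higher number from compound 1 to compound 3 (1.39 log units; beyond the scatter), so across these three compounds inhibition keeps weakening as the chain grows, and the modest 2.4-fold higher number from compound 1 to compound 2 (0.38 log units; beyond the scatter) gives way to large steps, with none of the three going against this trend. The two new steps are floors and not measured sizes, so no slope along the chain can be drawn from them: the limit of > 100000 nM in this assay, at which 1 of the 3 values shown sits.

For the compounds shown here, open is how a chain shorter than the one in compound 1, such as butyl, would read, and at which length between the chains of compound 2 and compound 3 the numbers reach the limit. Also open, from the compounds shown here alone, is whether an amine or a carboxylic acid at the far end of the long chain would keep the same trend.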